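A few compounds are considered here, and "the series" means these few. Any claim that something is new, unique, unknown or untested is made for them only; others in the source may bear on it.

Measured compounds and their values in a functional assay on MDA-MB-231 cells (Homo sapiens) for cytotoxicity, read by MTT assay, with a stated time of 72 h; a higher number here means a weaker inhibitor, a lower number a stronger inhibitor:
compound 1, `CN(C)CCCNc1nc(-c2ccc(NC(=O)Nc3ccccc3Cl)cc2)nc2ccsc12`: 590 nM
compound 2, `CN(C)CCCNc1nc(-c2ccc(NC(=O)Nc3ccc(Cl)cc3Cl)cc2)nc2ccsc12`: 1860 nM

Among the measured compounds shown here, compound 2 stands at the highest of the two numbers in this assay, and its only neighbour is compound 1, from which it is separated by a 3.2-fold higher number from compound 1 to compound 2 (0.50 log units; beyond the scatter). That step concerns a chloro on an aromatic carbon of the urea-bearing ring and says nothing about the amine-bearing chain.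

Compound 3, `CCN(CC)CCNc1nc(-c2ccc(NC(=O)Nc3ccc(Cl)cc3Cl)cc2)nc2ccsc12`, keeps the dichlorophenyl urea of compound 2 and differs from it only in that chain: diethylamino in place of (dimethylamino)methyl on a saturated chain carbon, two bonds along the chain from a nitrogen on an aromatic ring. For the measured compounds named here, no measured step touches this part of the molecule, so there is nothing to scale an expectation from. A step of about a 1.0-fold higher number from compound 2 to compound 3 (0.01 log units; within the scatter) is therefore expected, none beyond the scatter. Compound 3 is expected near 1900 nM, with a wide range of 600 nM to 6000 nM to reflect the absence of a precedent.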

Compound 3, half-maximal inhibitory concentration: 2480 nM
For compound 3 the middle estimate is 1.3-fold (0.12 log units) below the measured one, and the stated range covers the measured number.
By their numbers in this assay, from the lowest: compound 1; then compounds 2 and 3 (each within the scatter of the next).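

In this assay, diethylamino in place of (dimethylamino)methyl on a saturated chain carbon, two bonds along the chain from a nitrogen on an aromatic ring, gives a 1.3-fold higher number from compound 2 to compound 3 (0.12 log units; within the scatter), so the two compounds cannot be told apart in this assay. The earlier step, a 3.2-fold higher number from compound 1 to compound 2 (0.50 log units; beyond the scatter), concerned only the urea-bearing ring, whereas this one shows that, with the dichlorophenyl urea held constant, this exchange on the amine-bearing chain does not carry the read-out beyond the scatter. No measurement at hand bears on the reason for this result.

As far as these compounds go, whether the same chain exchange reads alike with the single-chloro urea of compound 1 remains open. Also open, from the compounds shown here alone, is how a ring amine such as morpholine or piperidine would read in place of diethylamino.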